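From 3-fluorophenyl to 4-fluorophenyl: a small expected step

The source may hold more compounds than are shown below. What is called first, only, known or untested is meant among the compounds shown, and "the series" means these compounds.

Of the compounds shown here, three sharing one core have been measured so far in a functional assay on HL-60 cells (Homo sapiens) for cytotoxicity, read by WST assay, with a stated time of 48 h (a higher number here means that more compound is needed for the effect, a lower number that less compound is needed), and the results sit close together. In that test compound 1 `Cc1ccccc1C[C@H]1COC(=O)[C@@H]1Cc1ccc(Cl)c(Cl)c1` gives 22000 nM and compound 2 `Cc1cccc(C[C@H]2COC(=O)[C@@H]2Cc2ccc(Cl)c(Cl)c2)c1` gives 22000 nM while compound 3 `O=C1OC[C@H](Cc2cccc(F)c2)[C@H]1Cc1ccc(Cl)c(Cl)c1` gives 14000 nM as its result. All three values lie within the usual scatter of one another, and compound 3 therefore stands level with the other two rather than apart from them.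

The next compound, compound 4 `O=C1OC[C@H](Cc2ccc(F)cc2)[C@H]1Cc1ccc(Cl)c(Cl)c1` in the same series, carries 4-fluorophenyl in place of 3-fluorophenyl on a saturated chain carbon bound to a saturated ring carbon. The structural count reads 4-fluorophenyl in place of 3-fluorophenyl on a saturated chain carbon bound to a saturated ring carbon and shows a swap of like for like.

Among the measured compounds shown here, no measured compound carries 4-fluorophenyl, so only parallels can guide the expectation. The closest is the exchange of 2-methylphenyl for 3-methylphenyl, which gave no change at the digits printed from compound 1 to compound 2 (within the scatter) as its outcome. Exchanging methyl for fluoro gave a 1.6-fold lower number from compound 2 to compound 3 (0.20 log units; within the scatter) and the exchange of 2-methylphenyl for 3-fluorophenyl gave a 1.6-fold lower number from compound 1 to compound 3 (0.20 log units; within the scatter) as a third small step.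

In this assay the expected size is a 1.1-fold higher number from compound 3 to compound 4 (0.03 log units; within the scatter) and thus nothing beyond the scatter in either direction. Compound 4 is estimated at 15000 nM with an expected range from 7000 nM to 28000 nM for the measurement to come.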

Compound 4, half-maximal effective concentration: 14000 nM
Beside the measured number, compound 4's estimate is 1.1-fold (0.03 log units) above it, and the stated range covers the measured number.
By their numbers in this assay, from the lowest: compounds 3, 4, 1 and 2 (each within the scatter of the next).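

In this assay, moving the fluorine from 3-fluorophenyl to 4-fluorophenyl on a saturated chain carbon bound to a saturated ring carbon gives no change at the digits printed from compound 3 to compound 4 (within the scatter), so the place of the fluorine on the phenyl ring makes no visible difference here, just as the place of the methyl made none in the earlier pair. Setting 4-fluorophenyl against the two methylphenyl groups gives a 1.6-fold lower number from compound 2 to compound 4 (0.20 log units; within the scatter) and a 1.6-fold lower number from compound 1 to compound 4 (0.20 log units; within the scatter), which means that all four compounds now read alike, with none going against that pattern, whichever of these small phenyl groups is present. Nothing in the data shown explains why these groups read alike.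

On these data alone, all four groups are phenyl rings carrying a single methyl or fluoro, so it stays open whether this position would respond to something different in kind, such as an amine or a carboxylic acid on the phenyl ring, or a longer chain between the ring and the core. The rest of the shared core is also the same in all four compounds, leaving open what a change elsewhere would do to these numbers.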